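A few compounds are considered here, and "the series" means these few. Any claim that something is new, unique, unknown or untested is made for them only; others in the source may bear on it.

For the measured compounds named here, only two compounds have a measured value so far, compound 1 `CN(C)c1ccc(Nc2nccc(-c3ccncc3)n2)cc1` and compound 2 `CC1CCN(c2ccc(Nc3nccc(-c4ccccn4)n3)cc2)CC1`. In a functional assay for inhibition, with Homo sapiens as the target (a lower number here means a stronger inhibitor, a higher number a weaker inhibitor), compound 2 gives 1900 nM and compound 1 gives 3700 nM. These two numbers lie within the usual scatter of repeated measurements, so they cannot be put in a reliable order, and compound 2 stands level with compound 1.

The next compound, compound 3 `CC1CCN(c2ccc(Nc3nccc(-c4ccncc4)n3)cc2)CC1`, has the same atoms as compound 2, joined differently: pyridin-4-yl in place of pyridin-2-yl on an aromatic carbon. In words, pyridin-4-yl takes the place of pyridin-2-yl on an aromatic carbon, and the rest of the molecule stays as it is.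

Going by the values given here, no measured pair shows the size of this swap on its own, so any forecast here is loose. Among the compounds with values here, the only guide is that compound 1 at 3700 nM and compound 2 at 1900 nM give no sign of a large gap. The expected step is a 1.2-fold higher number from compound 2 to compound 3 (0.08 log units; within the scatter), which would stay within the scatter. In this assay, compound 3 is estimated at 2300 nM, with an expected range from 800 nM to 6500 nM.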

Compound 3, half-maximal inhibitory concentration: 600 nM
Compound 3: the middle estimate sits 3.8-fold (0.58 log units) above what was measured; measured number below the stated range.
By their numbers in this assay, from the lowest: compound 3; then compounds 2 and 1 (each within the scatter of the next).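

In this assay, the placement of the nitrogen in the pyridine ring at this position matters: pyridin-4-yl in place of pyridin-2-yl gives a 3.2-fold lower number from compound 2 to compound 3 (0.50 log units; beyond the scatter), even though both groups have the same atoms and the same counts of hydrogen-bond donors and acceptors. Compound 1 and compound 2 could not show this, as they differ in two places at once, whereas compound 3 separates the two changes and shows that a second place in the molecule also counts: with pyridin-4-yl held fixed, 4-methylpiperidin-1-yl in place of dimethylamino gives a 6.2-fold lower number from compound 1 to compound 3 (0.79 log units; beyond the scatter). Nothing measured here accounts for either step, so the reason for these differences remains unknown.

The compounds shown leave open how pyridin-3-yl, the remaining pyridine arrangement, or a plain phenyl ring would compare at this position. They also leave open whether a morpholin-4-yl or piperazin-1-yl group could take the place of 4-methylpiperidin-1-yl, and whether the pyridin-4-yl step would keep its size alongside a different group there.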